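Sulfonyl substituent exchange and stability in liver microsomes

The source may report more compounds than this note shows. Statements on the series, on what has been measured and on what is new or still open speak of the compounds shown alone.

Measured so far in an ADME assay on microsomes from liver (Rattus norvegicus) for metabolic stability, with a stated time of 10 min; on this read-out lower numbers stand for a less stable compound and higher numbers for a more stable compound:
compound 1 `O=C(NS(=O)(=O)c1ccc(F)cc1)c1ccc(Nc2nc(NC3(c4ccc(Cl)cc4)CC3)nc(OCC(F)(F)F)n2)cc1` gives 99%
compound 2 `CC(C)S(=O)(=O)NC(=O)c1ccc(Nc2nc(NC3(c4ccc(Cl)cc4)CC3)nc(OCC(F)(F)F)n2)cc1` gives 96%
compound 3 `CCCCCNc1nc(Nc2ccc([N+](=O)[O-])cc2)nc(OCC(F)(F)F)n1` gives 35%

Compound 2 stands second highest of the three numbers. For the measured compounds named here, its nearest neighbour is compound 1, and the step of a number 3 percentage points lower from compound 1 to compound 2 (within the scatter) is the one measured exchange at the same place, isopropyl in place of 4-fluorophenyl on a sulfonyl sulfur. Going by the values given here, the furthest number is that of compound 3, which lies well below compound 2, beyond the scatter; no single-change step links compound 3 to compound 2, so the two values are only set side by side here.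

The next compound, compound 4 `CC(C)(C)OC(=O)NCCS(=O)(=O)NC(=O)c1ccc(Nc2nc(NC3(c4ccc(Cl)cc4)CC3)nc(OCC(F)(F)F)n2)cc1`, differs from compound 2 in one place: 2-((tert-butoxycarbonyl)amino)ethyl in place of isopropyl on a sulfonyl sulfur. Among the compounds with values here, the only measured step that bears on this is a number 3 percentage points lower from compound 1 to compound 2 (within the scatter), a change on the same sulfonyl sulfur that stayed within the scatter. No other listed step touches this position. On that basis a step of a number 3 percentage points lower from compound 2 to compound 4 (within the scatter) is expected, that is, nothing beyond the scatter in this assay, with the range widened a little because the entering group is larger than either group seen there so far.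

Compound 4 is therefore expected to give 93% in this assay, with a range from 80% to 99%.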

Compound 4, percent of the compound remaining: 93%
Compound 4: middle estimate and measured number agree at the digits printed; low and high end bracket the measured number.
By their numbers in this assay, from the lowest: compound 3; then compounds 4, 2 and 1 (each within the scatter of the next).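

In this assay, the sulfonyl sulfur, whose other neighbour is an amide-type nitrogen, also accepts 2-((tert-butoxycarbonyl)amino)ethyl, an open chain of 10 heavy atoms with a hydrogen-bond donor and acceptors, in place of isopropyl with its 3 heavy atoms and neither, and the result is a number 3 percentage points lower from compound 2 to compound 4 (within the scatter). Set against the 4-fluorophenyl group on the same sulfur, the same chain gives a number 6 percentage points lower from compound 1 to compound 4 (within the scatter), so a ring, a branched alkyl group and this much larger chain are not separated at this position, and among compounds 1, 2 and 4 none goes against that reading. No measurement at hand explains why the read-out stays so level across these three groups.

As far as these compounds go, it remains open whether the free primary amine left once the tert-butoxycarbonyl group is gone, or a carboxylic acid at the end of the ethyl chain, would hold the same level in this assay. A longer chain carrying the same tert-butoxycarbonyl amino group would show how far this tolerance at the sulfonyl sulfur extends.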